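Changing the amide aryl group of a p300 inhibitor

The source may report more compounds than this note shows. Statements on the series, on what has been measured and on what is new or still open speak of the compounds shown alone.

Compound 1 `O=C(Nc1ccc2[nH]c(=O)[nH]c2c1)[C@H]1CCCN1C(=O)C1(c2cccc(Cl)c2)CCCC1`: 0.398 nM
Compound 2 `COc1ccc(NC(=O)[C@H]2CCCN2C(=O)C2(c3ccc(Cl)cc3)CCCC2)cc1`: 7.94 nM
Compound 3 `O=C(Nc1cnc2[nH]ncc2c1)[C@H]1CCCN1C(=O)C1(c2cccc(Cl)c2)CCCC1`: 15.9 nM

In an assay on isolated protein for inhibition of histone acetyltransferase p300 (Homo sapiens), with a stated time of 60 min (on this read-out higher numbers stand for weaker inhibition and lower numbers for stronger inhibition), compound 3 holds the highest of the three numbers. It is separated from compound 1 by the step of a 40-fold higher number from compound 1 to compound 3 (1.60 log units; beyond the scatter), whereas compound 2 lies within the scatter of compound 3. Compound 4 `COc1ccc(NC(=O)[C@H]2CCCN2C(=O)C2(c3cccc(Cl)c3)CCCC2)nc1` carries a group of 8 heavy atoms (6 carbon, 1 nitrogen, 1 oxygen; one six-membered aromatic ring with 1 hetero atom) in place of a group of 9 heavy atoms (6 carbon, 3 nitrogen; one five-membered aromatic ring with 2 hetero atoms, one six-membered aromatic ring with 1 hetero atom), on an amide-type nitrogen. Going by the values given here, the only measured step at this amide nitrogen, a 40-fold higher number from compound 1 to compound 3 (1.60 log units; beyond the scatter), was large, but it concerned a different pair of groups. Compound 4 has no measured neighbour structurally closer than compound 2, which gives 7.94 nM in this assay, so no step beyond the scatter is expected here. Compound 4 is estimated at 10 nM, with a range of 2 nM to 50 nM. The expected step of a 1.6-fold lower number from compound 3 to compound 4 (0.20 log units; within the scatter) would stay within the scatter.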

Compound 4, half-maximal inhibitory concentration: 2 nM
For compound 4 the middle estimate is 5.0-fold (0.70 log units) above the measured one; the range from low to high includes it.
By their numbers in this assay, from the lowest: compound 1; then compound 4; then compounds 2 and 3 (each within the scatter of the next).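

At this amide nitrogen, in this assay, the 5-methoxypyridin-2-yl group gives an 8.0-fold lower number from compound 3 to compound 4 (0.90 log units; beyond the scatter), showing that a single six-membered aromatic ring with no hydrogen-bond donor can beat the fused group of compound 3. The same group still falls short of the fused group of compound 1, with a 5.0-fold higher number from compound 1 to compound 4 (0.70 log units; beyond the scatter). Nothing available explains either step. The compounds shown do not separate the contribution of the methoxy group from that of the ring nitrogen. On these data alone, how an amine or a carboxylic acid would fare in place of the methoxy group also remains open.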